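The source may hold more compounds than are shown below. What is called first, only, known or untested is meant among the compounds shown, and "the series" means these compounds.

Measured so far in an ADME assay on HEL cells (Homo sapiens) for cytotoxicity; on this read-out lower numbers stand for higher toxicity in this test and higher numbers for lower toxicity in this test:
compound 1 `O=C(COc1cccc2ccccc12)N/N=C/c1ccc(O)cc1`: 20 ug/mL
compound 2 `C/C(=N\NC(=O)COc1cccc2ccccc12)c1cccc([N+](=O)[O-])c1`: 20 ug/mL
compound 3 `O=C(COc1cccc2ccccc12)N/N=C/c1ccc([N+](=O)[O-])cc1`: 20 ug/mL

In this assay compound 1 stands level with compounds 2 and 3 at the digits shown; all three values coincide, so no ordering among them can be drawn. Among the measured compounds shown here, the one single-point step measured, no change at the digits printed from compound 1 to compound 3 (within the scatter), is the only guide and lies within the scatter.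

Compound 4 `O=C(COc1cccc2ccccc12)N/N=C/c1ccccc1Cl` differs from compound 1 by 2-chlorophenyl in place of 4-hydroxyphenyl on a carbon with a double bond to nitrogen. For the measured compounds named here, no measured step exchanges the whole aryl group; the nearest comparison is the step from compound 1 to compound 3, which left the value unchanged. On that basis the expected step is no change at the digits printed from compound 1 to compound 4 (within the scatter), none beyond the scatter. Compound 4 is therefore estimated at 20 ug/mL, with a range from 10 ug/mL to 40 ug/mL.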

Compound 4, minimum cytotoxic concentration: 100 ug/mL
Compound 4: middle estimate off by 5.0-fold (0.70 log units), on the low side; the measured number lies above the stated range.
By their numbers in this assay, from the lowest: compounds 1, 2 and 3 (each within the scatter of the next); then compound 4.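

In this assay, the aryl group on the carbon with a double bond to nitrogen does affect the read-out: 2-chlorophenyl in place of 4-hydroxyphenyl gives a clear step (a 5.0-fold higher number from compound 1 to compound 4 (0.70 log units; beyond the scatter)), which the nitro for hydroxy exchange (no change at the digits printed from compound 1 to compound 3 (within the scatter)) had not suggested. This single step cannot separate the loss of hydroxy from the arrival of chlorine or its new place. No evidence bears on the cause of this step.

Still open, from the compounds shown here alone, is whether unsubstituted phenyl or 4-chlorophenyl would give the same read-out. Going by these compounds, the effect of a 4-aminophenyl group is also open.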